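Methoxy in place of chloro on an aminophenyl ketone

This account rests on a few compounds, and the source may have more. Where it says the series, first, only, none or still open, it means among the compounds named here.

Measured compounds:
compound 1, `CC(=N)NCCC(=O)c1ccccc1N`: 22.3%
compound 2, `CC(=N)NCCC(=O)c1cc(Cl)ccc1N`: 99.1%

In an assay for inhibition of Nitric oxide synthase, inducible (Homo sapiens), with a stated time of 30 min, tested at 1 mM (a higher number here means more inhibition at the concentration tested (going by the name of the read-out), a lower number less inhibition), compound 2 gives 99.1%, the highest of the two numbers, while compound 1 gives 22.3%. Compound 3, `COc1ccc(N)c(C(=O)CCNC(C)=N)c1`, differs from compound 2 by methoxy in place of chloro on an aromatic carbon. Within the data shown here, the one measured step, a number 76.8 percentage points higher from compound 1 to compound 2 (beyond the scatter), shows how strongly the read-out depends on what sits on this aromatic carbon, but no measured pair tells whether methoxy behaves like chloro or like hydrogen there. Compound 3 is therefore expected to land between the two, a step of a number 39.1 percentage points lower from compound 2 to compound 3 (beyond the scatter) downward in this assay. The estimate for compound 3 is 60%, within 20% to 98%.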

Compound 3, a percentage reported as inhibition, at one concentration (the size of the read-out at that concentration, not a potency): 97.6%
The estimate for compound 3 lay 37.6 percentage points below the measured number, within the range that was stated.
By their numbers in this assay, from the lowest: compound 1; then compounds 3 and 2 (each within the scatter of the next).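

In this assay, methoxy in place of chloro on this aromatic carbon gives a number 1.5 percentage points lower from compound 2 to compound 3 (within the scatter), so the two groups cannot be told apart here. Methoxy in place of hydrogen gives a number 75.3 percentage points higher from compound 1 to compound 3 (beyond the scatter), so the large rise is not confined to chloro: both groups stand well clear of the hydrogen of compound 1. Nothing available bears on why these two groups match. From the compounds shown here alone, whether an amine or a carboxylic acid on this carbon would match them remains open. A reading at one concentration also leaves open whether compound 2 and compound 3 differ in potency.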